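This account rests on a few compounds, and the source may have more. Where it says the series, first, only, none or still open, it means among the compounds named here.

Compound 1 `CCCCCCCN1CCC(C(=O)Nc2cc(Cl)c(N)cc2OC)CC1` gives > 10 mg/kg in a functional assay on the whole organism for antagonist activity, with Mus musculus as the target (a lower number here means that less compound is needed, a higher number that more compound is needed for the effect), a limit of the assay rather than a number.
Compound 2 `CCCCCCN1CCC(C(=O)Nc2cc(Cl)c(N)cc2OC)CC1` gives > 10 mg/kg, also a limit.
Compound 3 `COc1cc(N)c(Cl)cc1NC(=O)C1CCN(Cc2cccc(C#N)c2)CC1` gives > 4 mg/kg, again a limit.

Compound 2 thus stands only at a limit, and the two other values are limits as well. Compound 4 `CCCCCN1CCC(C(=O)Nc2cc(Cl)c(N)cc2OC)CC1` differs from compound 2 by hydrogen in place of methyl on a saturated chain carbon, five bonds along the chain from an amine nitrogen in a ring. The measured step closest to this change is a step that the two limits leave unreadable from compound 1 to compound 2; the two others, a step that the two limits leave unreadable from compound 1 to compound 3 and a step that the two limits leave unreadable from compound 2 to compound 3, are equally unreadable. For the measured compounds named here, no direction and no size of step can be drawn from them, so nothing beyond the usual scatter is predicted. Since all values shown sit at the limit of > 10 mg/kg in this assay, at which 2 of the 3 values shown sit, or (the limit of > 4 mg/kg in this assay, at which 1 of the 3 values shown sits), compound 4 is estimated at 15 mg/kg, with a range from 5 mg/kg to 50 mg/kg, and most probably reported as a limit once more. This corresponds to an expected step that the limit leaves unreadable from compound 2 to compound 4.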

Compound 4, dose for half-maximal effect: > 10 mg/kg
Compound 4: no number, only a limit; the forecaster's own chance of this, stated with the estimate: 80%; the middle value does not contradict the limit.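

Compound 4 gives only a limit, as do compound 1, compound 2 and compound 3, so none of the steps to compound 4 can be read. The compounds shown leave open whether changing the group on the ring nitrogen alters the dose needed in this assay at all.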